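A 2-hydroxyphenyl swap in a series at its limit

The source may hold more compounds than are shown below. What is called first, only, known or untested is meant among the compounds shown, and "the series" means these compounds.

In an ADME assay on HepG2 cells (Homo sapiens) for cytotoxicity (on this read-out lower numbers stand for an effect already at smaller amounts and higher numbers for an effect only at larger amounts of compound), three compounds have been measured:
Compound 1 (`Cc1ccc(S(=O)(=O)N[C@@H](CC(=O)NC(C)(C)C)C(=O)NCCNC(=O)Nc2ccccc2)cc1`) gives > 11000 nM (a limit, not a number)
Compound 2 (`Cc1ccc(S(=O)(=O)N[C@@H](CC(=O)NC(C)(C)C)C(=O)NCCNC(=O)c2ccccc2F)cc1`) gives > 11000 nM (a limit, not a number)
Compound 3 (`Cc1ccc(S(=O)(=O)N[C@@H](CC(=O)NC(C)(C)C)C(=O)NCCNC(=O)c2cc(C)ccc2F)cc1`) gives > 11000 nM (a limit, not a number)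

Compound 3 therefore has no number of its own, only a limit, and the same holds for compound 1 and compound 2. The whole picture so far is the limit of > 11000 nM in this assay, at which 3 of the 3 values shown sit, and nothing more.

Compound 4 (`Cc1ccc(S(=O)(=O)N[C@@H](CC(=O)NC(C)(C)C)C(=O)NCCNC(=O)c2ccccc2O)cc1`) differs from compound 3 in one place (2-hydroxyphenyl in place of 2-fluoro-5-methylphenyl on a carbonyl carbon), with 2-hydroxyphenyl in place of 2-fluoro-5-methylphenyl on a carbonyl carbon.

The nearest measured evidence is a step that the two limits leave unreadable from compound 2 to compound 3 together with a step that the two limits leave unreadable from compound 1 to compound 2 and a step that the two limits leave unreadable from compound 1 to compound 3 in the same part of the molecule. None of these has a readable size, so they set no measured scale for this swap. Still, every change made here has left the compound at the limit, so no step beyond the usual scatter is expected. The estimated change is a step that the limit leaves unreadable from compound 3 to compound 4 and no more than that scatter.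

In this assay the expected value for compound 4 is 15000 nM as an estimate, with an expected range from 9000 nM to 30000 nM and quite possibly only a limit again.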

Compound 4, half-maximal effective concentration: > 11000 nM
Compound 4: a limit, no number; the forecaster's own chance of this, stated with the estimate: 85%; the middle value does not contradict the limit.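

In this assay compound 4 gives > 11000 nM, which is a limit and not a number. Its steps from compound 1, compound 2 and compound 3 therefore cannot be read. The compounds shown leave open how far any of them differ from one another in this assay, and which change, if any, would give a real number, as the whole picture remains a single limit: the limit of > 11000 nM in this assay, at which 4 of the 4 values shown sit.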